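Adding a benzyl group to the amide nitrogen

A few compounds are considered here, and "the series" means these few. Any claim that something is new, unique, unknown or untested is made for them only; others in the source may bear on it.

Compound 1 `C=C[C@@](C)(/C=C/c1ccc(O)c(/C=C/C(=O)O)c1)CCC=C(C)C`: > 43400 nM (a limit)
Compound 2 `C=C[C@@](C)(/C=C/c1ccc(O)c(/C=C/C(N)=O)c1)CCC=C(C)C`: > 43400 nM (a limit)

In a functional assay on NALM-6 cells (Homo sapiens) for cytotoxicity, with a stated time of 72 h (a higher number here means that more compound is needed for the effect, a lower number that less compound is needed), compound 2 gives > 43400 nM, which is a limit and not a number, so any readable change from it can only run towards lower values. Among the measured compounds shown here, the measured series so far comes down to the limit of > 43400 nM in this assay, at which 2 of the 2 values shown sit.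

Compound 3 `C=C[C@@](C)(/C=C/c1ccc(O)c(/C=C/C(=O)NCc2ccc(C(F)(F)F)cc2)c1)CCC=C(C)C` carries 4-(trifluoromethyl)benzyl in place of hydrogen on an amide-type nitrogen. For the measured compounds named here, the only measured step that bears on this is a step that the two limits leave unreadable from compound 1 to compound 2. It concerns the same carbonyl carbon but gives no size to carry over. Going by the values given here, the data hold no measured step for a substituent on the amide nitrogen, so the expectation is loose, and a further limit in this assay remains quite possible.

The expected step is an at least 2.1-fold lower number from compound 2 to compound 3 (0.33 log units; beyond the scatter), towards lower values.

For compound 3 the estimated value is 20000 nM, with an expected range from 6000 nM to 60000 nM.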

Compound 3, half-maximal effective concentration: > 43400 nM
Compound 3 gave a limit, no number; the forecaster's own chance of this, stated with the estimate: 45%; middle value at least 2.1-fold (0.33 log units) away from the limit.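

In this assay compound 3 gives > 43400 nM, which is a limit and not a number. Among the compounds shown here, no step can therefore be read between compound 2 and compound 3. The compounds shown leave open whether any substituent on the amide nitrogen yields a measurable value in this assay.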